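Hydroxy for iodo on the aminophenyl ring of compound 2

A few compounds are considered here, and "the series" means these few. Any claim that something is new, unique, unknown or untested is made for them only; others in the source may bear on it.

In a functional assay on MDA-MB-468 cells (Homo sapiens) for inhibition (on this read-out lower numbers stand for stronger inhibition and higher numbers for weaker inhibition), compound 2 (`Nc1ccc(-c2nc3ccccc3s2)c(I)c1`) gives only a limit, < 0.1 nM. Its relatives stand no differently: compound 1 (`Nc1ccc(-c2nc3ccccc3s2)c(Br)c1`) gives < 0.1 nM in this assay, likewise a limit, and compound 3 (`COc1ccc2nc(-c3ccc(N)cc3I)sc2c1`) gives < 0.1 nM, again a limit. Because of the limit of < 0.1 nM in this assay, at which 3 of the 3 values shown sit, neither a step that the two limits leave unreadable from compound 1 to compound 2 nor a step that the two limits leave unreadable from compound 2 to compound 3 can be read in size. Compound 4 (`Nc1ccc(-c2nc3ccccc3s2)c(O)c1`) differs from compound 2 by hydroxy in place of iodo on an aromatic carbon. Among the measured compounds shown here, no measured step bears on this exchange, so no direction can be drawn from the measured compounds; a change beyond the scatter is treated as possible. Compound 4 is therefore expected near 5 nM, in the range 0.1 nM to 300 nM. The estimated step is an at least 50-fold higher number from compound 2 to compound 4 (1.69 log units; beyond the scatter).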

Compound 4, half-maximal inhibitory concentration: > 10000 nM
Compound 4 gave a limit, no number; the forecaster's own chance of this, stated with the estimate: 20%; at least 2000-fold (3.30 log units) between middle value and limit.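

Where the earlier steps could not be read in size, this exchange gives the first readable change at this aromatic carbon in this assay: hydroxy in place of iodo brings an at least 100000-fold higher number from compound 2 to compound 4 (5.00 log units; beyond the scatter), and hydroxy in place of bromo brings an at least 100000-fold higher number from compound 1 to compound 4 (5.00 log units; beyond the scatter). The position is thus not indifferent to what it carries, since bromo and iodo sit at one end of the read-out and hydroxy at the other. Both steps give only a minimum size: the limit of > 10000 nM in this assay, at which 1 of the 4 values shown sits.

From the compounds shown here alone, how chloro, methyl or an amine at this carbon would read remains open. So does whether bromo and iodo differ at all.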